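From an Acetyl Group to a Second Ring

The source may report more compounds than this note shows. Statements on the series, on what has been measured and on what is new or still open speak of the compounds shown alone.

In an ADME assay (liver) for metabolic stability, with Liver microsome (Rattus norvegicus) as the target, read by LC-MS, using microsomes, with a stated time of 30 min, tested at 4 uM (on this read-out lower numbers stand for a less stable compound and higher numbers for a more stable compound), compound 2 `COCCn1c(-c2ccccc2Cl)nc2c(N3CCN(C(C)=O)CC3)nc(C)nc21` gives 95%, the higher of two numbers, while compound 1 `CCN1CCN(c2nc(C)nc3c2nc(-c2ccccc2Cl)n3CCOC)CC1` gives 53%. That one measured step, a number 42 percentage points higher from compound 1 to compound 2 (beyond the scatter), put acetyl in place of ethyl on an amine nitrogen in a ring. Compound 3 `COCCn1c(-c2ccccc2Cl)nc2c(N3CCN4C(=O)CCC4C3)nc(C)nc21` differs from compound 2 in one place: a group of 10 heavy atoms (7 carbon, 2 nitrogen, 1 oxygen; one five-membered non-aromatic ring with 1 hetero atom, one six-membered non-aromatic ring with 2 hetero atoms) in place of a group of 9 heavy atoms (6 carbon, 2 nitrogen, 1 oxygen; one six-membered non-aromatic ring with 2 hetero atoms), on an aromatic carbon. Going by the values given here, the measured step bears only in part: compound 3 keeps a carbonyl like compound 2, yet no measured step tests an added five-membered non-aromatic ring. Only a small change, within the usual scatter, is expected, a number 8 percentage points lower from compound 2 to compound 3 (within the scatter). For compound 3 the estimated value is 87%, with an expected range of 65% to 98%.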

Compound 3, percent of the compound remaining: 91%
Estimate against measurement, compound 3: 4 percentage points below; measured number inside the range.
By their numbers in this assay, from the lowest: compound 1; then compounds 3 and 2 (each within the scatter of the next).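

In this assay, the two-ring group with its five-membered non-aromatic ring in place of 4-acetylpiperazin-1-yl gives a number 4 percentage points lower from compound 2 to compound 3 (within the scatter), so the two groups cannot be told apart here. The distance from the ethyl compound also holds, at a number 38 percentage points higher from compound 1 to compound 3 (beyond the scatter), which shows that on this aromatic carbon the carbonyl goes with a high number both in an open acetyl group and inside a second ring. Nothing measured here explains why either group differs from the ethyl group. As far as these compounds go, whether the carbonyl itself matters stays open. A methanesulfonyl group on that ring nitrogen, or the same two-ring group without its carbonyl, would bear on that question.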